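Dropping the Chloro Group: What Compound 4 May Show

The source may hold more compounds than are shown below. What is called first, only, known or untested is meant among the compounds shown, and "the series" means these compounds.

Compound 1 `COc1cc(OC)c(C(=O)/C=C/c2ccc(Cl)cc2)c(OC)c1` — 0%
Compound 2 `COc1cccc(/C=C/C(=O)c2c(O)cc(OC)cc2OC)c1` — 37%
Compound 3 `COc1cc(O)c(C(=O)/C=C/c2ccccc2SC)c(OC)c1` — 28%

In a functional assay on HCT-116 cells (Homo sapiens), read by fluorescence and BrdU incorporation, with a stated time of 48 h, tested at 25 uM (a higher number here means a weaker effect of the compound at the concentration tested, a lower number a stronger effect), compound 1 gives 0%, the lowest of the three numbers and therefore the strongest effect seen here. Compound 3 gives 28%, a gap beyond the scatter, and compound 2 gives 37%, the widest gap of the set.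

Compound 4 `COc1cc(OC)c(C(=O)/C=C/c2ccccc2)c(OC)c1` differs from compound 1 by hydrogen in place of chloro on an aromatic carbon. Going by the values given here, no measured pair shows this same change, so its size is unknown from the data. Because compound 1 already gives 0% the number can hardly fall further, and a modest rise is expected, a number 15 percentage points higher from compound 1 to compound 4 (beyond the scatter). Compound 4 is accordingly estimated at 15%, with a range from 0% to 45%.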

Compound 4, a percentage reported as activity, at one concentration (the size of the read-out at that concentration, not a potency): 2.6%
Beside the measured number, compound 4's estimate is 12.4 percentage points above it; the range from low to high includes it.
By their numbers in this assay, from the lowest: compounds 1 and 4 (each within the scatter of the next); then compounds 3 and 2 (each within the scatter of the next).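

Replacing the chloro with hydrogen on the aromatic carbon gives a number 2.6 percentage points higher from compound 1 to compound 4 (within the scatter) in this assay. Going by these compounds alone, this is the first change at a single place in the set, and it shows that the low number of compound 1 does not depend on the chloro, since the step from 4-chlorophenyl to phenyl leaves the number where it was. At this position, para to a large group, the shared core therefore tolerates losing that atom without a change beyond the scatter.

From the compounds shown here alone, whether an amine or a carboxylic acid at the same place would keep the number this low remains open. No evidence on the reason for this result is at hand.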